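Nitro in place of hydrogen on the core of compound 1

The source may report more compounds than this note shows. Statements on the series, on what has been measured and on what is new or still open speak of the compounds shown alone.

compound 1 `c1ccc(COc2ccc(OCCOCCNC3CCCC3)cc2)cc1`: 24800 nM
compound 2 `c1ccc(COc2ccc(OCCOCCNc3ccncc3)cc2)cc1`: 20600 nM
compound 3 `COc1cc(OCCOCCNC2CCCC2)ccc1OCc1ccccc1`: 44600 nM

In a functional assay on SK-OV-3 cells (Homo sapiens) for inhibition, read by CCK-8 assay, with a stated time of 70 h (on this read-out lower numbers stand for stronger inhibition and higher numbers for weaker inhibition), compound 1 gives 24800 nM, the second highest of the three numbers. Its two neighbours are close: a 1.2-fold lower number from compound 1 to compound 2 (0.08 log units; within the scatter) and a 1.8-fold higher number from compound 1 to compound 3 (0.25 log units; within the scatter), both within the scatter, so none of the three can be ranked against another. Compound 4 `O=[N+]([O-])c1cccc(COc2ccc(OCCOCCNC3CCCC3)cc2)c1` differs from compound 1 by nitro in place of hydrogen on an aromatic carbon. Going by the values given here, no measured step introduces a nitro group, so no step bears on it directly; the closest in kind is the step from compound 1 to compound 3, a small group entering on an aromatic carbon, which stayed within the scatter. The account therefore expects no step beyond the scatter in this assay for compound 4, a 1.0-fold higher number from compound 1 to compound 4 (0.00 log units; within the scatter). Compound 4 is estimated at 25000 nM, with a range from 9000 nM to 70000 nM.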

Compound 4, half-maximal inhibitory concentration: 15400 nM
The estimate for compound 4 lay 1.6-fold (0.21 log units) above the measured number; measured number inside the range.
By their numbers in this assay, from the lowest: compounds 4, 2, 1 and 3 (each within the scatter of the next, the first and the last beyond it).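

In this assay the change from phenyl to 3-nitrophenyl gives a 1.6-fold lower number from compound 1 to compound 4 (0.21 log units; within the scatter), so this place, meta to a large group, takes a nitro group without a step beyond the scatter. It is the first change shown on this ring, as the earlier steps altered other places in compound 1. No measurement shown here accounts for this result.

From the compounds shown here alone, whether an amine or a carboxylic acid in the same place would give a step beyond the scatter stays open. So does the effect of nitro elsewhere on this ring.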